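This account rests on a few compounds, and the source may have more. Where it says the series, first, only, none or still open, it means among the compounds named here.

Working notes on the series. The shared core carries a trimethoxyphenyl-bearing member, compound 1 `COc1cc(-c2cc(/C=C/C(=O)c3ccc(N)cc3)[nH]n2)cc(OC)c1OC`, which in a functional assay on SW-620 cells (Homo sapiens) for cytotoxicity, read by sulforhodamine B assay, with a stated time of 48 h, tested at 1 uM (on this read-out higher numbers stand for a weaker effect at the one concentration tested and lower numbers for a stronger effect), gives 82%. Among the three numbers in this assay compound 1 stands second highest. Going by the values given here, compound 2 `COc1ccc(-c2cc(/C=C/C(=O)c3ccc(N)cc3)[nH]n2)cc1OC` gives 95%, and the step of a number 13 percentage points higher from compound 1 to compound 2 (beyond the scatter) is the only single-point change measured so far; it concerns the aryl on the core, not the ketone side. Compound 3 `COc1ccc(-c2cc(/C=C/C(=O)c3cc(OC)c(OC)c(OC)c3)[nH]n2)cc1OC` differs from compound 1 in two places; in this assay compound 3 gives 70%. Among the compounds with values here, that is a lower number than the one of compound 1, beyond the scatter.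

Compound 4 `COc1cc(-c2cc(/C=C/C(=O)c3ccc(F)c(F)c3)[nH]n2)cc(OC)c1OC` is not yet measured. Its change from compound 1 is 3,4-difluorophenyl in place of 4-aminophenyl on a carbonyl carbon. Within the data shown here, no measured step alters the group on the carbonyl carbon alone, so nothing bears directly on this change; compound 3 shows only that a different group there can coincide with a lower number. A modest step downward, or none beyond the scatter, is therefore expected: a number 7 percentage points lower from compound 1 to compound 4 (within the scatter). Compound 4 is estimated at 75%, between 50% and 98%.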

Compound 4, a percentage reported as activity, at one concentration (the size of the read-out at that concentration, not a potency): 93%
Compound 4: middle estimate off by 18 percentage points, on the low side, within the range that was stated.
By their numbers in this assay, from the lowest: compound 3; then compound 1; then compounds 4 and 2 (each within the scatter of the next).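

Going by these compounds alone, this is the first measured step that alters the group on a carbonyl carbon alone: in this assay, 3,4-difluorophenyl in place of 4-aminophenyl gives a number 11 percentage points higher from compound 1 to compound 4 (beyond the scatter) with the rest of the structure held fixed. The group at this position can therefore shift the read-out on its own, and this replacement shifts it toward a weaker effect at the one concentration tested. Nothing measured here accounts for the step.

As far as these compounds go, the step swaps the amine and the two fluorines together, so the share of each stays open; an unsubstituted phenyl group or a single fluorine on the phenyl at this position would begin to separate them. Also open, from the compounds shown here alone, is whether the same replacement gives a similar step when the aryl on the core carries a different set of methoxy groups.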